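Dropping one methoxy group from a dimethoxy aniline

A few compounds are considered here, and "the series" means these few. Any claim that something is new, unique, unknown or untested is made for them only; others in the source may bear on it.

Compound 1, with the structure `COc1ccc(Nc2cccc3c(C)c(C)sc23)cc1OC`, was tested in a functional assay for inhibition, with a stated time of 2 h, tested at 0.0312 g/L (on this read-out lower numbers stand for less inhibition and higher numbers for more inhibition at the one concentration tested (going by the name of the read-out)), and gave 91.4%. Its closest neighbour among the measured compounds is compound 2, `COc1ccc(Nc2cccc3c(C)c(C)sc23)cc1`, which in this assay gave 96.8%. The change between them, a number 5.4 percentage points higher from compound 1 to compound 2 (within the scatter), shows that removing one of the two methoxy groups left the read-out essentially unchanged, since the two numbers lie within the usual scatter of each other.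

Compound 3, `COc1cccc(Nc2cccc3c(C)c(C)sc23)c1`, has not yet been measured. It differs from compound 1 in one place: hydrogen in place of methoxy on an aromatic carbon. Within the data shown here, this is the same kind of change as the one from compound 1 to compound 2, only the other methoxy group is removed. Because that measured step, a number 5.4 percentage points higher from compound 1 to compound 2 (within the scatter), stayed within the scatter, no step beyond the scatter is expected here either. Compound 3 is therefore estimated to give 90% in this assay, with a range from 72% to 99%. The expected step is a number 1.4 percentage points lower from compound 1 to compound 3 (within the scatter).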

Compound 3, a percentage reported as inhibition, at one concentration (the size of the read-out at that concentration, not a potency): 62.9%
Estimate against measurement, compound 3: 27.1 percentage points above, and the stated range ends above it.
By their numbers in this assay, from the lowest: compound 3; then compounds 1 and 2 (each within the scatter of the next).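

In this assay, swapping methoxy for hydrogen does not have one fixed outcome: on the aromatic carbon para to a large group and ortho to a methoxy group, it gives a number 28.5 percentage points lower from compound 1 to compound 3 (beyond the scatter), while removing the other methoxy group gives a number 5.4 percentage points higher from compound 1 to compound 2 (within the scatter). The two methoxy groups of compound 1 therefore do not count equally in this read-out, and the methoxy group at this place matters in a way the earlier pair could not show. Nothing at hand explains the difference.

From the compounds shown here alone, whether a hydroxyl group, a fluorine atom or a longer ethoxy chain at this place would bring the number closer to that of compound 1 remains open. Also open, going by these compounds, is how the compounds would compare at other concentrations, as a reading at one concentration is not a potency.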